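Two Fluorines on the Benzyl Group of Compound 1

The source may report more compounds than this note shows. Statements on the series, on what has been measured and on what is new or still open speak of the compounds shown alone.

Compound 1 `Cn1cc(-c2cnc3[nH]cc(-c4cnn(Cc5ccccc5)c4)c3c2)cn1` carries a plain benzyl group on a saturated chain carbon bound to an aromatic nitrogen. Among the measured compounds shown here, in a functional assay on KARPAS-299 cells (Homo sapiens) for cytotoxicity, read by XTT assay, with a stated time of 72 h (on this read-out lower numbers stand for stronger inhibition and higher numbers for weaker inhibition), compound 1 gives 3000 nM, the highest of the three numbers measured so far. Compound 2 `Cn1cc(-c2cnc3[nH]cc(-c4cnn(Cc5ccc(F)cc5)c4)c3c2)cn1` gives 1780 nM, and compound 3 `Cn1cc(-c2cnc3[nH]cc(-c4cnn(Cc5cccc(C(F)(F)F)c5)c4)c3c2)cn1` gives 1010 nM. The step of a 1.7-fold lower number from compound 1 to compound 2 (0.23 log units; within the scatter) stays within the scatter, while the step of a 3.0-fold lower number from compound 1 to compound 3 (0.47 log units; beyond the scatter) is a modest gain; the two measured neighbours are compared by the step of a 1.8-fold lower number from compound 2 to compound 3 (0.25 log units; within the scatter), which again stays within the scatter.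

Compound 4 `Cn1cc(-c2cnc3[nH]cc(-c4cnn(Cc5cc(F)cc(F)c5)c4)c3c2)cn1` differs from compound 1 in a single spot: 3,5-difluorophenyl in place of phenyl on a saturated chain carbon bound to an aromatic nitrogen. Both measured steps from compound 1 put a fluorine-containing group on the phenyl ring, and both moved the number downward, one within and one beyond the scatter. Compound 4 places two fluorines on that ring, so the step of a 2.0-fold lower number from compound 1 to compound 4 (0.30 log units; within the scatter) is expected to be a modest lowering, at or just beyond the edge of the scatter. Compound 4 is therefore expected to give about 1500 nM, with a likely range from 700 nM to 3200 nM.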

Compound 4, half-maximal inhibitory concentration: 664 nM
The estimate for compound 4 lay 2.3-fold (0.35 log units) above the measured number; the measured number lies below the stated range.
By their numbers in this assay, from the lowest: compounds 4, 3, 2 and 1 (each within the scatter of the next, the first and the last beyond it).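

On this benzyl group, two fluorines do what the single fluorine of the 4-fluorophenyl group did not: in this assay the 3,5-difluorophenyl group gives a 4.5-fold lower number from compound 1 to compound 4 (0.65 log units; beyond the scatter) and also a 2.7-fold lower number from compound 2 to compound 4 (0.43 log units; beyond the scatter) as a second clear step beyond the scatter. The 3-(trifluoromethyl)phenyl group also clears the scatter from plain phenyl, yet a 1.5-fold lower number from compound 3 to compound 4 (0.18 log units; within the scatter) is a step within the scatter, so these two substituted rings cannot be ranked against each other. No measurement at hand explains why fluorine on this ring lowers the number.

The 4-fluorophenyl and 3,5-difluorophenyl groups differ both in how many fluorines they carry and in where those fluorines sit, so the compounds shown cannot separate the count from the placement. All of the rings shown are plain or carry only fluorine-containing groups, which leaves open what an amine or a carboxylic acid on this ring would do, or a longer chain in place of the single saturated carbon that links the ring to the aromatic nitrogen.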